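The source may report more compounds than this note shows. Statements on the series, on what has been measured and on what is new or still open speak of the compounds shown alone.

In a functional assay on ECV-304 cells (Homo sapiens) for cytotoxicity (a higher number here means a weaker inhibitor, a lower number a stronger inhibitor), three compounds with a shared core have been tested so far. Compound 1 (`Cc1ccc(/C=C2\SC(=S)N(NS(=O)(=O)c3ccccc3)C2=O)cc1`) reads > 50000 nM and this is a limit of the assay, not a number. Compound 2 (`Cc1cccc(/C=C2\SC(=S)N(NS(=O)(=O)c3ccccc3)C2=O)c1`) reads > 50000 nM and this too is a limit. Compound 3 (`O=C1/C(=C/c2ccc(Cl)c(F)c2)SC(=S)N1NS(=O)(=O)c1ccccc1`) reads > 50000 nM and this is again a limit. Compound 3 therefore stands with the other two at one shared ceiling (the limit of > 50000 nM in this assay, at which 3 of the 3 values shown sit).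

Compound 4 (`O=C1/C(=C/c2ccc(Cl)c(Cl)c2)SC(=S)N1NS(=O)(=O)c1ccccc1`) differs from compound 3 by chloro in place of fluoro on an aromatic carbon, so 4-chloro-3-fluorophenyl becomes 3,4-dichlorophenyl. The measured steps that bear on this change are a step that the two limits leave unreadable from compound 1 to compound 3 and a step that the two limits leave unreadable from compound 2 to compound 3 together with a step that the two limits leave unreadable from compound 1 to compound 2 and none of them gives a size to carry over. No direction can be drawn from them, so no step beyond the usual scatter is expected, and the expected step is small (a step that the limit leaves unreadable from compound 3 to compound 4). For compound 4 the estimated value is 60000 nM with an expected range of 30000 nM to 100000 nM and another limit is the likeliest report.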

Compound 4, half-maximal inhibitory concentration: > 50000 nM
Compound 4: no number, only a limit (the forecaster's own chance of this, stated with the estimate: 80%); the middle value does not contradict the limit.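

No step can be read among compound 1, compound 2, compound 3 and compound 4, because each gives only a limit and no number: the limit of > 50000 nM in this assay, at which 4 of the 4 values shown sit. The compounds shown leave open how far apart these four truly lie in this assay, and whether any of them would give a measurable value.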